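The source may hold more compounds than are shown below. What is called first, only, known or untested is meant among the compounds shown, and "the series" means these compounds.

Measured compounds:
compound 1 `COCC(C)Oc1cccc2ccc(N)nc12` — 606 nM in an assay on cells with melanin-concentrating hormone receptor 1 (Homo sapiens) as the target, read by radioligand binding; a lower number here means a stronger inhibitor, a higher number a weaker inhibitor
compound 2 `CC#CCCOc1cccc2ccc(N)nc12` — compound 2 reports only a limit here, > 2000 nM
compound 3 `Nc1ccc2cccc(OCC3CC4CCC3C4)c2n1` — 137 nM

Compound 1 holds the highest of the two numbers; compound 3 sits at a lower number, beyond the scatter. The step to compound 2 reads an at least 3.3-fold higher number from compound 1 to compound 2 (0.51 log units; beyond the scatter), a change at the same oxygen on the aromatic ring, ending at the limit of > 2000 nM in this assay, at which 1 of the 3 values shown sits.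

Compound 4 `CC(C)Oc1cccc2ccc(N)nc12` differs from compound 1 by hydrogen in place of methoxy on a saturated chain carbon, two bonds along the chain from an oxygen on an aromatic ring. Within the data shown here, no measured step removes a methoxy from this chain; the step to compound 2 changes the whole group and bears only loosely. For compound 4 a step near the scatter is expected, a 1.3-fold higher number from compound 1 to compound 4 (0.12 log units; within the scatter), estimated at 800 nM (range 300 nM to 2500 nM).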

Compound 4, half-maximal inhibitory concentration: 437 nM
For compound 4 the middle estimate is 1.8-fold (0.26 log units) above the measured one; the measured number falls inside the stated range.
By their numbers in this assay, from the lowest: compound 3; then compounds 4 and 1 (each within the scatter of the next). At a limit, above all of these: compound 2.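

In this assay, the methoxy on the 1-(methoxymethyl)ethyl group can be lost without a change beyond the scatter (a 1.4-fold lower number from compound 1 to compound 4 (0.14 log units; within the scatter)). The plain isopropyl ether therefore stays level with compound 1, whereas pent-3-yn-1-yl does not (an at least 4.5-fold lower number from compound 2 to compound 4 (0.66 log units; beyond the scatter)). Compound 2 gives only a limit, not a number: (the limit of > 2000 nM in this assay, at which 1 of the 4 values shown sits).

On these data alone, whether an amine or a carboxylic acid in place of that methoxy would also leave the number within the scatter stays open. So does whether a longer branched ether chain would keep this level.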